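Sulfonyl Aryl Swap in a Pyrrolidinone Sulfonamide Series

This account rests on a few compounds, and the source may have more. Where it says the series, first, only, none or still open, it means among the compounds named here.

Compound 1 `O=C1[C@@H](NS(=O)(=O)c2cc3ccc(Cl)cc3s2)CCN1Cc1cc2c[nH]ccc-2n1`: 53%
Compound 2 `O=C1[C@@H](NS(=O)(=O)c2cc3c(Cl)nccc3s2)CCN1Cc1cc2[nH]cccc-2n1`: 50%

In an assay on isolated protein for inhibition of coagulation factor X (Oryctolagus cuniculus), tested at 0.5 uM (on this read-out lower numbers stand for less inhibition and higher numbers for more inhibition at the one concentration tested (going by the name of the read-out)), compound 1 gives 53%. In the same this assay compound 2 gives 50%, which is the lower of the two numbers shown, but the gap to compound 1 lies within the scatter, so neither compound can be called the stronger. For the measured compounds named here, no pair of measured compounds differs in a single place, so no step is available from the measured set.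

Compound 3 `O=C1[C@@H](NS(=O)(=O)c2cc3ccc(Cl)cc3s2)CCN1Cc1cc2[nH]cccc-2n1` differs from compound 2 as follows: a group of 10 heavy atoms (8 carbon, 1 sulfur, 1 chlorine; one five-membered aromatic ring with 1 hetero atom, one six-membered aromatic ring of carbon only) in place of a group of 10 heavy atoms (7 carbon, 1 nitrogen, 1 sulfur, 1 chlorine; one five-membered aromatic ring with 1 hetero atom, one six-membered aromatic ring with 1 hetero atom), on a sulfonyl sulfur. The group that enters is the group that sits on the sulfonyl sulfur of compound 1, and compound 1 and compound 2 stand within the scatter of each other. The step from compound 2 to compound 3 is therefore expected to be a number 1 percentage points higher from compound 2 to compound 3 (within the scatter), none beyond the scatter. Compound 3 is expected to give 51% in this assay, with a range from 36% to 66%.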

Compound 3, a percentage reported as inhibition, at one concentration (the size of the read-out at that concentration, not a potency): 64%
Beside the measured number, compound 3's estimate is 13 percentage points below it; the range from low to high includes it.
By their numbers in this assay, from the lowest: compounds 2 and 1 (each within the scatter of the next); then compound 3.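

In this assay, placing 6-chloro-1-benzothiophen-2-yl on the sulfonyl sulfur gives a number 14 percentage points higher from compound 2 to compound 3 (beyond the scatter), so the group at this position does matter when the rest of the molecule is held fixed. The change on the saturated chain carbon bound to an amide-type nitrogen in a ring gives a number 11 percentage points higher from compound 1 to compound 3 (beyond the scatter), showing that this second place also counts, something the values of compound 1 and compound 2, which differ in both places, could not reveal. No measurement at hand offers an explanation for either step. On these data alone, it remains open what a bromine or a methyl group in place of the chlorine of the 6-chloro-1-benzothiophen-2-yl group would do. Also open, as far as these compounds go, is whether these steps would hold at other concentrations.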